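A few compounds are considered here, and "the series" means these few. Any claim that something is new, unique, unknown or untested is made for them only; others in the source may bear on it.

Working notes on the series.

Three compounds have numbers in a functional assay on ACHN cells (Homo sapiens) for cytotoxicity, read by sulforhodamine B assay, tested at 10 uM; on this read-out higher numbers stand for more inhibition at the one concentration tested (going by the name of the read-out) and lower numbers for less inhibition. Compound 1, `CC(=O)OC[C@H]1O[C@@H](n2cc(-c3cn(Cc4ccc(C(C)C)cc4)nn3)c(=O)[nH]c2=O)C[C@@H]1OC(C)=O`, gives 92.2%. Compound 2, `CC(=O)OC[C@H]1O[C@@H](n2cc(-c3cc(C)no3)c(=O)[nH]c2=O)C[C@@H]1OC(C)=O`, gives 96.4%. Compound 3, `CC(C)(C)c1ccc(Cn2cc(-c3cn([C@H]4C[C@H](O)[C@@H](CO)O4)c(=O)[nH]c3=O)nn2)cc1`, gives 102%. On its face the number for compound 1 is the smallest of the three, but its gap to compound 2 and its gap to compound 3 both fall within the usual scatter of repeated measurements, so no order among the three can be read from these values; the three numbers are level with one another at the single concentration tested.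

Compound 4, `CC(=O)OC[C@H]1O[C@@H](n2cc(-c3cn(Cc4ccc(C(C)(C)C)cc4)nn3)c(=O)[nH]c2=O)C[C@@H]1OC(C)=O`, has not yet been measured. It differs from compound 1 by methyl in place of hydrogen on a saturated chain carbon bound to an aromatic carbon and two saturated chain carbons. Going by the values given here, no pair of measured compounds differing in exactly one place is available, so the size of this step has no direct precedent here. Compound 3 carries the same 4-(tert-butyl)benzyl and gives 102%, which is within the scatter of compound 1.

With the numbers of the whole series level with one another, the step from compound 1 to compound 4 is expected to be small, a number 2.8 percentage points higher from compound 1 to compound 4 (within the scatter), and not beyond the scatter in either direction. Compound 4 is therefore estimated at 95% in this assay, with an expected range from 84% to 104%.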

Compound 4, a percentage reported as inhibition, at one concentration (the size of the read-out at that concentration, not a potency): 97.2%
Compound 4: middle estimate off by 2.2 percentage points, on the low side, within the range that was stated.
By their numbers in this assay, from the lowest: compounds 1, 2, 4 and 3 (each within the scatter of the next).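

The pair of compound 1 and compound 4 gives the series its first step that differs in one place: in this assay, isopropyl to tert-butyl on the 4-substituted benzyl group, with the rest of the structure unchanged, gives a number 5 percentage points higher from compound 1 to compound 4 (within the scatter). At this position, therefore, methyl in place of hydrogen on the saturated chain carbon bound to an aromatic carbon and two saturated chain carbons leaves the read-out level, and the added heavy atom produces no change that can be separated from repeated-measurement scatter. No supporting measurement bears on this result, so the level read-out stands as an observation only.

From the compounds shown here alone, whether an amine, a carboxylic acid or a longer chain in place of the tert-butyl would give a step beyond the scatter remains open, since this single step covers only isopropyl and tert-butyl. Because this assay reports the size of the read-out at one concentration rather than a potency, the compounds shown also leave open whether compound 1 and compound 4 would stay level at lower concentrations.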